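A Nitrophenol in Place of Bromophenyl on Compound 3

This account rests on a few compounds, and the source may have more. Where it says the series, first, only, none or still open, it means among the compounds named here.

Three compounds of this series have readings so far. In a functional assay on DU-145 cells (Homo sapiens) for inhibition, read by trypan blue exclusion, with a stated time of 96 h (a lower number here means a stronger inhibitor of growth, a higher number a weaker inhibitor of growth), compound 1 `O=C(/C(=C\c1ccc(OCc2ccccc2)cc1)SCc1ccc(Cl)cc1)c1ccc(Cl)cc1` gives 1000 nM, and compound 2 `Cc1ccc(S/C(=C/c2ccc(Cl)c(Cl)c2)C(=O)c2ccc(Br)cc2)cc1` gives 50000 nM. Compound 3 `O=C(O)c1ccc(C(=O)/C(=C\c2ccc(Br)cc2)SCc2ccc(F)cc2)cc1` gives > 100000 nM, which is a limit of the assay and not a number. As far as these compounds go, compound 3 is thus the one case of the limit of > 100000 nM in this assay, at which 1 of the 3 values shown sits, and its true position on the scale remains unknown.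

The next compound is compound 4 `O=C(O)c1ccc(C(=O)/C(=C\c2ccc(O)c([N+](=O)[O-])c2)SCc2ccc(F)cc2)cc1`, which keeps the rest of compound 3 and changes one group: 4-hydroxy-3-nitrophenyl in place of 4-bromophenyl on a double-bonded chain carbon bound to a double-bonded chain carbon. The 4-hydroxy-3-nitrophenyl group takes the place of the 4-bromophenyl group on a double-bonded chain carbon bound to a double-bonded chain carbon.

Among the compounds with values here, no pair of measured compounds differs in only one place, so the series offers no direct guide to the size of this step in this assay. The starting reading for compound 3 is > 100000 nM, a limit, so compound 4 is expected to remain a weak inhibitor of growth, and another limit is a real possibility. The expected change is an at least 2.5-fold lower number from compound 3 to compound 4 (0.39 log units; beyond the scatter), a modest move towards stronger inhibition if a number is obtained at all. For compound 4 the estimated value is 40000 nM, with an expected range from 8000 nM to 100000 nM.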

Compound 4, concentration for 50% growth inhibition: > 100000 nM
Compound 4 was reported as a limit; the forecaster's own chance of this, stated with the estimate: 45%; at least 2.5-fold (0.39 log units) between middle value and limit.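

Compound 3 and compound 4 are both reported only as limits in this assay, and the step between them cannot be read. The compounds shown leave open where either compound truly lies on the scale, and whether 4-hydroxy-3-nitrophenyl in place of 4-bromophenyl changes growth inhibition at all.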